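Fluorine for Bromine on the Far Benzyl Group

The source may report more compounds than this note shows. Statements on the series, on what has been measured and on what is new or still open speak of the compounds shown alone.

In a functional assay on MCF7 cells (Homo sapiens) for inhibition, read by MTT assay, with a stated time of 48 h, tested at 10 uM (on this read-out lower numbers stand for less inhibition of growth and higher numbers for more inhibition of growth at the one concentration tested), compound 1 `C#CCOc1ccc(/C=C/C(=O)c2ccc(Br)cc2)cc1` gives 45%, compound 2 `C#CCOc1ccc(/C=C/C(=O)c2ccc(OC)cc2)cc1` gives 32%, and compound 3 `O=C(/C=C/c1ccc(OCc2cn(Cc3cccc(Br)c3)nn2)cc1)c1ccc(Br)cc1` gives 36%. Compound 3 thus stands second of the three, and its gaps to compound 2 and to compound 1 both lie within the scatter. Compound 4 `O=C(/C=C/c1ccc(OCc2cn(Cc3ccc(F)cc3)nn2)cc1)c1ccc(Br)cc1` differs from compound 3 in one place: 4-fluorophenyl in place of 3-bromophenyl on a saturated chain carbon bound to an aromatic nitrogen. Going by the values given here, the only measured step, a number 13 percentage points lower from compound 1 to compound 2 (beyond the scatter), concerns the bromo group at the other end of the shared core, not the benzyl group that changes here, so no measured step bears directly on this change. With nothing to argue for a shift, the estimated step is no change at the digits printed from compound 3 to compound 4 (within the scatter), within the scatter. Compound 4 is therefore estimated at 36%, in the range 20% to 52%.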

Compound 4, percent growth inhibition at one concentration: 37%
Compound 4: middle estimate off by 1 percentage points, on the low side; the range from low to high includes it.
By their numbers in this assay, from the lowest: compounds 2, 3, 4 and 1 (each within the scatter of the next, the first and the last beyond it).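

Going by these compounds alone, at this position, on a saturated chain carbon bound to an aromatic nitrogen, 4-fluorophenyl in place of 3-bromophenyl gives a number 1 percentage points higher from compound 3 to compound 4 (within the scatter), the first reading of any change on the far benzyl group. The halogen and its place on the ring change at once, so this step cannot separate the two. No available evidence bears on this result.

From the compounds shown here alone, whether a benzyl group carrying an amine or a carboxylic acid would read differently in this assay stays open. So does whether methoxy in place of bromo would lower the number in compounds carrying the benzyl group, as it does from compound 1 to compound 2.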